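Swapping benzylamino for 2-ethoxyethoxy on a shared core

The compounds below may be only part of what the source reports. "The series", "measured", "known", "first", "only" and "open" are said of these compounds alone.

Of the compounds shown here, three built on a shared core have been tested in an ADME assay on Vero cells (Chlorocebus sabaeus) for cytotoxicity, read by resazurin assay, with a stated time of 3 days; on this read-out lower numbers stand for stronger inhibition and higher numbers for weaker inhibition. Compound 1 `O=C(Nc1cc2nc(C3CCCCC3)[nH]c2cc1N1CCCC1)OCC(F)(F)F` gives only a limit of the assay, > 100 ug/mL. Compound 2 `Cc1ccc(C(=O)Nc2cc3nc(C4CCCCC4)[nH]c3cc2N2CCCC2)cc1` likewise gives a limit, > 100 ug/mL. Compound 3 `O=C(NCc1ccccc1)Nc1cc2nc(C3CCCCC3)[nH]c2cc1N1CCCC1` also gives a limit, > 100 ug/mL. Because all three values sit at the same limit (the limit of > 100 ug/mL in this assay, at which 3 of the 3 values shown sit), the steps between them cannot be read: a step that the two limits leave unreadable from compound 1 to compound 2, a step that the two limits leave unreadable from compound 1 to compound 3 and a step that the two limits leave unreadable from compound 2 to compound 3. Compound 4 `CCOCCOC(=O)Nc1cc2nc(C3CCCCC3)[nH]c2cc1N1CCCC1` differs from compound 3 at one place: 2-ethoxyethoxy in place of benzylamino on a carbonyl carbon. For the measured compounds named here, no measured step bears on this change in a readable way, so no shift beyond the scatter can be foreseen. Compound 4 is therefore expected to remain at the limit, with an estimated step that the limit leaves unreadable from compound 3 to compound 4. The estimate for compound 4 is 150 ug/mL, ranging from 60 ug/mL to 400 ug/mL.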

Compound 4, half-maximal inhibitory concentration: > 100 ug/mL
Compound 4 ended at the assay's limit (the forecaster's own chance of this, stated with the estimate: 85%); the middle value lies beyond the limit too.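

The steps from compound 1, compound 2 and compound 3 to compound 4 cannot be read, because all four compounds share one limit: the limit of > 100 ug/mL in this assay, at which 4 of the 4 values shown sit. The compounds shown leave open whether changing the group on this carbonyl carbon can shift the read-out at all.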